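From 1-Methylpiperidin-4-yl to 4-Methylpiperazin-1-yl on Sulfonyl Sulfur

The source may report more compounds than this note shows. Statements on the series, on what has been measured and on what is new or still open speak of the compounds shown alone.

Three compounds that differ only in the group on the sulfonyl sulfur have been measured in an ADME assay on microsomes from liver (Homo sapiens) for pharmacokinetics, read by LC-MS, with a stated time of 60 min, tested at 1 uM; on this read-out lower numbers stand for slow clearance and higher numbers for fast clearance. With oxan-4-yl, compound 1 `O=C(NCc1ccc(S(=O)(=O)C2CCOCC2)cc1)N1Cc2ccncc2C1` gives 6 mL/min/kg. With oxan-3-yl, compound 2 `O=C(NCc1ccc(S(=O)(=O)C2CCCOC2)cc1)N1Cc2ccncc2C1` gives 7 mL/min/kg, and the size of this exchange is a 1.2-fold higher number from compound 1 to compound 2 (0.07 log units; within the scatter). With 1-methylpiperidin-4-yl, compound 3 `CN1CCC(S(=O)(=O)c2ccc(CNC(=O)N3Cc4ccncc4C3)cc2)CC1` gives 11 mL/min/kg. Compound 3 therefore stands within the scatter of both other compounds, as a 1.8-fold higher number from compound 1 to compound 3 (0.26 log units; within the scatter) and a 1.6-fold higher number from compound 2 to compound 3 (0.20 log units; within the scatter) show.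

Compound 4 `CN1CCN(S(=O)(=O)c2ccc(CNC(=O)N3Cc4ccncc4C3)cc2)CC1` has not yet been measured. It carries 4-methylpiperazin-1-yl in place of 1-methylpiperidin-4-yl on a sulfonyl sulfur. All three measured steps bear on this change, since each exchanges the group at the same place, and none of them exceeds the scatter. Within the data shown here, none of the measured compounds carries 4-methylpiperazin-1-yl, however, so this guidance is only indirect. No step beyond the scatter is expected in this assay, and no direction can be favoured with confidence. The estimate amounts to an expected 1.1-fold lower number from compound 3 to compound 4 (0.04 log units; within the scatter). For compound 4 the expected clearance is 10 mL/min/kg, with an estimated range from 5 mL/min/kg to 20 mL/min/kg.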

Compound 4, clearance: 9 mL/min/kg
Compound 4: the middle estimate sits 1.1-fold (0.05 log units) above what was measured, and the stated range covers the measured number.
By their numbers in this assay, from the lowest: compounds 1, 2, 4 and 3 (each within the scatter of the next).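

In this assay, 4-methylpiperazin-1-yl on the sulfonyl sulfur joins the three earlier groups without a step beyond the scatter against any of them: against 1-methylpiperidin-4-yl (a 1.2-fold lower number from compound 3 to compound 4 (0.09 log units; within the scatter)), against oxan-3-yl (a 1.3-fold higher number from compound 2 to compound 4 (0.11 log units; within the scatter)) and against oxan-4-yl (a 1.5-fold higher number from compound 1 to compound 4 (0.18 log units; within the scatter)). Among these compounds, the exchange of 1-methylpiperidin-4-yl for 4-methylpiperazin-1-yl replaces one carbon of the group with nitrogen, at 7 heavy atoms on both sides, and this swap within a six-membered non-aromatic ring leaves the number within the scatter, so the first direct comparison for this group agrees with what the other three compounds show among themselves. Nothing available gives a measured property that would account for these small steps, and none is offered here.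

As far as these compounds go, all four groups are six-membered non-aromatic rings, so it stays open whether an open chain, such as a simple ethyl group, or a group carrying a carboxylic acid or a primary amine would give a step beyond the scatter in this assay. Changes elsewhere on the shared core also remain untested by these compounds.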